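This account rests on a few compounds, and the source may have more. Where it says the series, first, only, none or still open, it means among the compounds named here.

Measured in an in vitro ADME assay on microsomes (Mus musculus) for metabolic stability; on this read-out lower numbers stand for a shorter-lived compound and higher numbers for a longer-lived compound:
- compound 1 `CCNC(=O)Nc1ccc(-c2nc(N3CC4CCC(C3)O4)c3cnn(C4CCC5(CC4)OCCO5)c3n2)cc1`: 0.45 h
- compound 2 `CNC(=O)Nc1ccc(-c2nc(N3CC4CCC(C3)O4)c3cnn([C@H]4CC[C@@H](O)CC4)c3n2)cc1`: > 0.5 h (a limit)
- compound 3 `CNC(=O)Nc1ccc(-c2nc(N3CC4CCC(C3)O4)c3cnn(C4CCC5(CC4)OCCCO5)c3n2)cc1`: > 0.5 h (a limit)

Compound 3 has no number on this read-out, and it stands at the limit of > 0.5 h in this assay, at which 2 of the 3 values shown sit. Compound 4 `CCn1ncc2c(N3CC4CCC(C3)O4)nc(-c3ccc(NC(=O)NC)cc3)nc21` differs from compound 3 by one change, (a group of 2 heavy atoms (2 carbon; no ring) in place of a group of 11 heavy atoms (9 carbon, 2 oxygen; one six-membered non-aromatic ring of carbon only, one six-membered non-aromatic ring with 2 hetero atoms), on an aromatic nitrogen). Ethyl enters on the aromatic nitrogen of the five-membered aromatic ring, where the larger two-ring group leaves. Among the measured compounds shown here, the only measured step at this nitrogen is a step that the two limits leave unreadable from compound 2 to compound 3, so it offers no size or direction to carry over. For the measured compounds named here, the only number in the set belongs to compound 1, at 0.45 h. On that basis, no step beyond the scatter is expected in this assay, although the limit on compound 3 keeps this expectation loose. For compound 4 the expected half-life is 0.5 h, with an estimated range from 0.2 h to 1.1 h. The expected step is a number no higher from compound 3 to compound 4 (the limit leaves the size open).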

Compound 4, half-life: > 0.5 h
Compound 4 ended at the assay's limit (the forecaster's own chance of this, stated with the estimate: 50%); the middle value sits exactly at the limit.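

In this assay compound 4 gives > 0.5 h, a limit and not a number. Compound 2 and compound 3 also stand at limits, so neither step to compound 4 can be read. The compounds shown leave open whether the group on the aromatic nitrogen affects the half-life at all.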